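Azido to Amino: Expected Cytotoxicity of Compound 4

A few compounds are considered here, and "the series" means these few. Any claim that something is new, unique, unknown or untested is made for them only; others in the source may bear on it.

Of the compounds shown here, three have so far been tested in a toxicity assay on the whole organism (J774 cells) for cytotoxicity, with Mus musculus as the target, read by MTT assay, with a stated time of 24 h, tested at 10 uM; a lower number here means a stronger effect, a higher number a weaker effect of the compound at the concentration tested. Compound 1 `NC[C@H]1O[C@H](O[C@H]2[C@H](O)[C@@H](O)[C@H](N)C[C@@H]2N)[C@H](N)[C@@H](OCc2ccc3ccccc3c2)[C@@H]1OCc1ccc2ccccc2c1` gives 79.1%, compound 3 `NC[C@H]1O[C@H](O[C@H]2[C@H](O)[C@@H](O)[C@H](N)C[C@@H]2N)[C@H](N)[C@@H](OCCCc2ccc3ccccc3c2)[C@@H]1OCCCc1ccc2ccccc2c1` gives 87.7%, and compound 2 `CCCCCCCCCO[C@@H]1[C@@H](N)[C@@H](OC[C@H](O)CN=[N+]=[N-])O[C@H](CN)[C@H]1OCCCCCCCCC` gives 62.2%. Compound 2 thus stands lowest of the three numbers, which on this read-out means the strongest effect on the cells at the concentration tested. Its nearest neighbour is compound 1, whose number lies higher by more than the usual scatter, and compound 3 lies higher still, also beyond the scatter.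

Compound 4 `CCCCCCCCCO[C@@H]1[C@@H](N)[C@@H](OC[C@H](O)CN)O[C@H](CN)[C@H]1OCCCCCCCCC` is compound 2 with a single change: amino in place of azido on a saturated chain carbon, two bonds along the chain from an oxygen on a saturated carbon. Among the compounds with values here, no pair of measured compounds shows this exact change, so no step of known size can be borrowed from them. The three measured compounds differ from one another in many places at once, so their spread says little about one swap of this kind. On that basis the step from compound 2 to compound 4 is expected to be small, a number 5.2 percentage points lower from compound 2 to compound 4 (within the scatter), leaning if anywhere toward a lower number, that is a somewhat stronger effect, but most likely staying within the scatter. Compound 4 is therefore estimated to give 57% in this assay, with a range from 38% to 76%.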

Compound 4, a percentage reported as activity, at one concentration (the size of the read-out at that concentration, not a potency): 88%
Beside the measured number, compound 4's estimate is 31 percentage points below it; measured number outside the range, above it.
By their numbers in this assay, from the lowest: compound 2; then compounds 1, 3 and 4 (each within the scatter of the next).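

In this assay, within the data shown here, the change from azido to amino on a saturated chain carbon, two bonds along the chain from an oxygen on a saturated carbon, gives the first step that can be read for a single change: a number 25.8 percentage points higher from compound 2 to compound 4 (beyond the scatter). This shows that the position is not a silent one: with everything else in the molecule kept the same, this one swap moves the number up, which on this read-out means a weaker effect on the cells at the concentration tested. Nothing available here explains why the step has this size.

The pair cannot separate what losing azido contributes from what gaining amino contributes, and a single pair cannot tell whether the same swap elsewhere on the molecule, or on a different core, would move the number in the same way. A hydroxyl, a methylamino or a guanidine in this same place, or a longer chain carrying the amino group in place of the 3-amino-2-hydroxypropyl, would show whether the step is specific to amino or is shared by other groups.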